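Pyrrolidinone to thiazole swap on the aryl ether linker

The compounds below may be only part of what the source reports. "The series", "measured", "known", "first", "only" and "open" are said of these compounds alone.

Measured compounds:
compound 1 `Cc1cc(OCc2cccc3nccn23)cc(C)c1-c1cccc(COc2ccc3c(c2)OC[C@H]3CC(=O)O)c1` gives 15 nM in an assay on CHO cells for displacement of a labelled ligand from Free fatty acid receptor 1 (Homo sapiens), read by scintillation counting, with a stated time of 90 min, in the presence of a further agent that is not named here; on this read-out higher numbers stand for weaker inhibition and lower numbers for stronger inhibition
compound 2 `Cc1cc(OCCCN2CCCC2=O)cc(C)c1-c1cccc(COc2ccc3c(c2)OC[C@H]3CC(=O)O)c1` gives 31 nM in this assay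

Compound 2 has the highest of the two numbers; the step of a 2.1-fold higher number from compound 1 to compound 2 (0.32 log units; beyond the scatter) separates it from compound 1. Compound 3 `Cc1nc(C)c(COc2cc(C)c(-c3cccc(COc4ccc5c(c4)OC[C@H]5CC(=O)O)c3)c(C)c2)s1` is not yet measured; it differs from compound 2 by 2,4-dimethyl-1,3-thiazol-5-yl in place of 2-(2-oxopyrrolidin-1-yl)ethyl on a saturated chain carbon bound to an oxygen on an aromatic ring. Going by the values given here, the only step that bears on this, a 2.1-fold higher number from compound 1 to compound 2 (0.32 log units; beyond the scatter), exchanged an aromatic bicyclic group for the lactam and raised the number modestly. Returning to an aromatic ring is therefore expected to give a modest lower number, a 1.6-fold lower number from compound 2 to compound 3 (0.19 log units; within the scatter). Compound 3 is estimated at 20 nM, range 8 nM to 50 nM.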

Compound 3, inhibition constant: 12 nM
For compound 3 the middle estimate is 1.7-fold (0.22 log units) above the measured one, and the stated range covers the measured number.
By their numbers in this assay, from the lowest: compounds 3 and 1 (each within the scatter of the next); then compound 2.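

In this assay the aromatic thiazole group does better at this place than the lactam chain (a 2.6-fold lower number from compound 2 to compound 3 (0.41 log units; beyond the scatter)), so two aromatic groups of different size now both give lower numbers than the lactam chain. The fused bicyclic group of compound 1 is not required, since the single thiazole ring matches it (a 1.3-fold lower number from compound 1 to compound 3 (0.10 log units; within the scatter)). Nothing measured here explains either step. 

Still open, on these data alone, is whether the two methyl groups on the thiazole matter, and whether an unsubstituted thiazole, a phenyl ring or a basic amine on the same chain would hold the number.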